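Replacing the Amide Partner in Compound 1

The compounds below may be only part of what the source reports. "The series", "measured", "known", "first", "only" and "open" are said of these compounds alone.

Compound 1 `CCN(CC)S(=O)(=O)c1ccc(S(=O)(=O)N2CCC[C@@H](C(=O)N3CCC(F)(F)CC3)C2)cc1` is the starting point. In a functional assay on BXPC-3 cells (Homo sapiens) for inhibition, read by MTT assay, with a stated time of 7 days (on this read-out lower numbers stand for stronger inhibition and higher numbers for weaker inhibition), compound 1 gives 120 nM, the second highest of the three numbers measured. Compound 2 `CCC(CC)S(=O)(=O)c1ccc(S(=O)(=O)N2CCC[C@@H](C(=O)N3CCC(F)(F)CC3)C2)cc1` gives 40 nM in this assay, and a 3.0-fold lower number from compound 1 to compound 2 (0.48 log units; beyond the scatter). Compound 3 `O=C([C@@H]1CCCN(S(=O)(=O)c2ccc(S(=O)(=O)N3CC[C@H](O)C3)cc2)C1)N1CCC(F)(F)CC1` gives 580 nM in this assay, and a 4.8-fold higher number from compound 1 to compound 3 (0.68 log units; beyond the scatter). Both of these steps alter the group on a sulfonyl sulfur at one end of the shared core, and they show that exchanges there move the number by modest amounts in either direction.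

Compound 4 `CCN(CC)S(=O)(=O)c1ccc(S(=O)(=O)N2CCC[C@@H](C(=O)N[C@@H]3CCOC3)C2)cc1` differs from compound 1 at the other end of the shared core: (oxolan-3-yl)amino in place of 4,4-difluoropiperidin-1-yl on a carbonyl carbon. Going by the values given here, none of the measured steps touches this carbonyl carbon, since compounds 1, 2 and 3 all carry the same 4,4-difluoropiperidin-1-yl group there. The measured steps therefore offer no direction for this exchange, only a sense that single changes on this core tend to shift the number modestly. The expected change is a 2.1-fold higher number from compound 1 to compound 4 (0.32 log units; beyond the scatter), a step not far beyond the scatter. Compound 4 is therefore estimated at 250 nM in this assay, with a deliberately wide range from 60 nM to 1000 nM.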

Compound 4, half-maximal inhibitory concentration: 2270 nM
For compound 4 the middle estimate is 9.1-fold (0.96 log units) below the measured one; measured number outside the range, above it.
By their numbers in this assay, from the lowest: compound 2; then compound 1; then compound 3; then compound 4.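

In this assay, the carbonyl carbon proves to be a sensitive position, with a 19-fold higher number from compound 1 to compound 4 (1.28 log units; beyond the scatter), whereas compounds 1, 2 and 3 all carry the same 4,4-difluoropiperidin-1-yl group there and so could not show this. The exchange alters several features in a single step: a six-membered ring bearing two fluorine atoms and no hydrogen-bond donor leaves, and a five-membered ring with an oxygen atom, a hydrogen-bond donor and a defined stereocentre enters. No available evidence explains the rise in the number, so this one step cannot say which of those features matters.

On these data alone, it remains open whether the ring size, the loss of the fluorine atoms or the gain of the amide hydrogen accounts for the shift, and plain piperidin-1-yl or 3,3-difluoropyrrolidin-1-yl on the same carbonyl carbon would begin to separate these features. As far as these compounds go, it is also open whether the pentan-3-yl group of compound 2 would lower the number to a similar degree when paired with (oxolan-3-yl)amino.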